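Changing the Aryl Amine on a Shared Core

This account rests on a few compounds, and the source may have more. Where it says the series, first, only, none or still open, it means among the compounds named here.

Compound 1 `Clc1ncnc2sc(Nc3cccc(Br)c3)nc12` and compound 2 `OC[C@@H]1CCCN1c1ncnc2sc(Nc3ccc(Cl)cc3)nc12` were both tested in a functional assay on CHO-K1 cells for antagonist activity at adenosine receptor A2b (Homo sapiens), read by 33P incorporation, with a stated time of 20 min, in the presence of a further agent that is not named here; a higher number here means a weaker inhibitor, a lower number a stronger inhibitor. For compound 1 the result is only a limit of the assay, > 10000 nM. For compound 2 the result is likewise only a limit, > 10000 nM, so compound 2 stands at the limit of > 10000 nM in this assay, at which 2 of the 2 values shown sit, rather than at a measured number. Compound 3 `OC[C@@H]1CCCN1c1ncnc2sc(Nc3cccc(Br)c3)nc12` has not been measured; it carries 3-bromophenyl in place of 4-chlorophenyl on a nitrogen on an aromatic ring. For the measured compounds named here, with no measured step to draw on, the step expected in this assay is a step that the limit leaves unreadable from compound 2 to compound 3, none beyond the scatter. Compound 3 is therefore estimated at 15000 nM, within 3000 nM to 60000 nM, most likely again reported only as a limit.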

Compound 3, inhibition constant: > 10000 nM
Compound 3 ended at the assay's limit; the forecaster's own chance of this, stated with the estimate: 75%; the middle value lies beyond the limit too.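

No step to compound 3 can be read from compound 1 or compound 2, as all three compounds share one limit: the limit of > 10000 nM in this assay, at which 3 of the 3 values shown sit.

The compounds shown leave open which change on the shared core, if any, would give a value inside the assay's range.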